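The source may report more compounds than this note shows. Statements on the series, on what has been measured and on what is new or still open speak of the compounds shown alone.

Compound 1 `CC(C(=O)NCc1ccc(C(F)(F)F)nc1SCCOc1ccccc1)c1ccc(NS(C)(=O)=O)c(F)c1`: 2.3 nM; compound 3 `CC(C(=O)NCc1ccc(C(F)(F)F)nc1SCCC(=O)N1CCCC1)c1ccc(NS(C)(=O)=O)c(F)c1`: 85 nM; compound 2 `CC(C(=O)NCc1ccc(C(F)(F)F)nc1SCCCO)c1ccc(NS(C)(=O)=O)c(F)c1`: "not active" (no number reported).

In an assay on CHO-K1 cells for antagonist activity at transient receptor potential cation channel subfamily V member 1 (Homo sapiens), read by FLIPR (a higher number here means a weaker inhibitor, a lower number a stronger inhibitor), compound 1 gives 2.3 nM and compound 3 gives 85 nM. Compound 2 was reported as not active in this assay, so no number stands for it; it is the point from which compound 4 `CC(C(=O)NCc1ccc(C(F)(F)F)nc1S(=O)(=O)C1CCCCC1)c1ccc(NS(C)(=O)=O)c(F)c1` departs. The change is cyclohexylsulfonyl in place of (3-hydroxypropyl)sulfanyl on an aromatic carbon. Among the measured compounds shown here, the only measured step, a 37-fold higher number from compound 1 to compound 3 (1.57 log units; beyond the scatter), shows that the group on the chain at this position shifts potency strongly. For the measured compounds named here, no measured pair tests the cyclohexylsulfonyl group itself, and compound 2 offers no number to step from, so the expectation for compound 4 rests on the spread seen between compound 1 and compound 3. Compound 4 is estimated at 20 nM, within 3 nM to 200 nM.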

Compound 4, inhibition constant: "not active" (no number reported)
No number was reported for compound 4, so the estimate cannot be set against anything.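

Compound 2 and compound 4 were both reported as not active in this assay, leaving no step to read between them, and nothing at hand explains this result. On these data alone, how the cyclohexylsulfonyl group itself affects potency remains open.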